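A few compounds are considered here, and "the series" means these few. Any claim that something is new, unique, unknown or untested is made for them only; others in the source may bear on it.

Three compounds have so far been measured in a functional assay for inhibition of sodium/hydrogen exchanger (Oryctolagus cuniculus); on this read-out higher numbers stand for weaker inhibition and lower numbers for stronger inhibition:

compound 1, `CCc1cc(Cl)c(S(C)(=O)=O)cc1C(=O)N=C(N)N`: 63 nM
compound 2, `CS(=O)(=O)c1cc(C(=O)N=C(N)N)c(F)cc1F`: 630 nM
compound 3, `Cc1cc(C2CCCCC2)c(S(C)(=O)=O)cc1C(=O)N=C(N)N`: 22 nM

All three share the same core and differ only in the groups attached to it. Compound 3 stands with the lowest number of the three in this assay. Compound 1 is nearest to it, and even that gap lies beyond the usual scatter of repeated measurements; compound 2 lies furthest away, by a much wider margin. Since a lower number means stronger inhibition, compound 3 is the strongest inhibitor among the three measured.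

Compound 4, `Cc1cc(Sc2ccccc2)c(S(C)(=O)=O)cc1C(=O)N=C(N)N`, has not yet been measured. It differs from compound 3 in one place: phenylsulfanyl in place of cyclohexyl on an aromatic carbon. For the measured compounds named here, no pair of measured compounds shows this same change, and compounds 1 and 2 differ from compound 3 in more than one place, so nothing measured isolates it directly. The step of a 1.8-fold higher number from compound 3 to compound 4 (0.26 log units; within the scatter) is expected to be small, toward a somewhat higher number, and may well fall within the usual scatter. Compound 4 is thus expected to give 40 nM, with a likely range from 12 nM to 150 nM.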

Compound 4, half-maximal inhibitory concentration: 14 nM
Compound 4: the middle estimate sits 2.9-fold (0.46 log units) above what was measured; low and high end bracket the measured number.
By their numbers in this assay, from the lowest: compounds 4 and 3 (each within the scatter of the next); then compound 1; then compound 2.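

Read by this assay the exchange of cyclohexyl for phenylsulfanyl is a 1.6-fold lower number from compound 3 to compound 4 (0.20 log units; within the scatter) and so leaves the two compounds level. For the compounds shown here, this is the first comparison here that changes only one place, and it shows that this aromatic carbon, ortho to a methylsulfonyl group and meta to a methyl group, can carry either a six-membered non-aromatic ring of carbon only or a six-membered aromatic ring attached through sulfur, with the numbers staying within ordinary repeat-to-repeat variation. Nothing available explains why these two different groups give such similar numbers.

Going by these compounds, two groups are a small sample, so it remains open how a phenoxy group, a phenyl ring attached directly, or a much smaller group such as methyl would read at this same carbon. Also open, on these data alone, is how an amine or a carboxylic acid would fare here, and whether this exchange would give a similar step on a core with something other than the methyl group.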